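The compounds below may be only part of what the source reports. "The series", "measured", "known", "first", "only" and "open" are said of these compounds alone.

Compound 1 `CNC(=O)c1cnc(N2CCN(C3CCN(Cc4ccc(Cl)cc4)CC3)[C@@H](C)C2)c(Cl)c1` holds the lower of the two numbers in a functional assay for antagonist activity at C-X-C chemokine receptor type 3 (Homo sapiens) (a lower number here means a stronger inhibitor, a higher number a weaker inhibitor), where compound 1 gives 32 nM. Compound 2 `CNC(=O)c1cnc(N2CCN(C3CCN(Cc4ccccn4)CC3)[C@@H](C)C2)c(Cl)c1` gives 7990 nM, and the step of a 250-fold higher number from compound 1 to compound 2 (2.40 log units; beyond the scatter) exchanges the 4-chlorophenyl on a saturated chain carbon bound to an amine nitrogen in a ring. Compound 3 `C[C@H]1CN(c2ncc(C(=O)NCc3ccc(F)c(F)c3)cc2Cl)CCN1C1CCN(Cc2ccc(Cl)cc2)CC1` differs from compound 1 at a different place: 3,4-difluorophenyl in place of hydrogen on a saturated chain carbon bound to an amide-type nitrogen. Going by the values given here, the one measured step does not touch the carbamoyl end, so no precedent bears on it. Lacking such a precedent, only a modest shift is expected, a 2.1-fold lower number from compound 1 to compound 3 (0.33 log units; beyond the scatter). Compound 3 is thus estimated at 15 nM, within 3 nM to 80 nM.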

Compound 3, half-maximal inhibitory concentration: 6 nM
For compound 3 the middle estimate is 2.5-fold (0.40 log units) above the measured one; the range from low to high includes it.
By their numbers in this assay, from the lowest: compound 3; then compound 1; then compound 2.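

In this assay, going by these compounds alone, the carbamoyl end accepts a much larger group without loss: the change from methylcarbamoyl to (3,4-difluorobenzyl)carbamoyl gives a 5.3-fold lower number from compound 1 to compound 3 (0.73 log units; beyond the scatter) and is the first measured change at this end. The added 3,4-difluorophenyl therefore improves on the small methyl amide, though no data given here account for the gain. As far as these compounds go, it remains open whether the two fluorines or the aromatic ring carry this gain; an unsubstituted benzyl or a longer chain such as 2-phenylethyl on the amide nitrogen would separate the two.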